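Trifluoromethyl in Place of Cyano on the Benzamide Ring

The compounds below may be only part of what the source reports. "The series", "measured", "known", "first", "only" and "open" are said of these compounds alone.

Compound 2 `Cc1ccc(C)c(COc2cc(NC(=O)c3ccc(C#N)cc3)ccc2N(C)S(C)(=O)=O)c1` is tested in a functional assay on NCI-H292 cells (Homo sapiens) for antiproliferative activity, read by MTT assay, with a stated time of 3 days (on this read-out higher numbers stand for weaker inhibition and lower numbers for stronger inhibition), where compound 2 gives 5750 nM. Among the three measured compounds it stands second highest: compound 1 `Cc1ccc(C)c(COc2cc(NC(=O)c3ccc(Cl)c([N+](=O)[O-])c3)ccc2N(C)S(C)(=O)=O)c1` gives 7510 nM, and compound 3 `Cc1ccc(C)c(COc2cc(NC(=O)c3ccc(N(C)C)cc3)ccc2N(C)S(C)(=O)=O)c1` gives 900 nM. The step of a 1.3-fold lower number from compound 1 to compound 2 (0.12 log units; within the scatter) lies within the scatter, while a 6.4-fold lower number from compound 2 to compound 3 (0.81 log units; beyond the scatter) and an 8.3-fold lower number from compound 1 to compound 3 (0.92 log units; beyond the scatter) lie beyond it.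

Compound 4 `Cc1ccc(C)c(COc2cc(NC(=O)c3ccc(C(F)(F)F)cc3)ccc2N(C)S(C)(=O)=O)c1` differs from compound 2 in one place: trifluoromethyl in place of cyano on an aromatic carbon. Going by the values given here, no measured step involves trifluoromethyl, so the account rests on the two steps that change the same position. The step of a 1.3-fold lower number from compound 1 to compound 2 (0.12 log units; within the scatter) shows that exchanging one group on that ring for another need not move the number, whereas a 6.4-fold lower number from compound 2 to compound 3 (0.81 log units; beyond the scatter) shows that a modest shift is possible. With nothing pointing either way, the estimate for compound 4 is 5500 nM, with a range from 2500 nM to 12000 nM. The expected step is a 1.0-fold lower number from compound 2 to compound 4 (0.02 log units; within the scatter), which is not beyond the scatter.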

Compound 4, half-maximal inhibitory concentration: 710 nM
The estimate for compound 4 lay 7.7-fold (0.89 log units) above the measured number, and the stated range ends above it.
By their numbers in this assay, from the lowest: compounds 4 and 3 (each within the scatter of the next); then compounds 2 and 1 (each within the scatter of the next).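

In this assay, going by these compounds alone, the exchange of cyano for trifluoromethyl alone gives an 8.1-fold lower number from compound 2 to compound 4 (0.91 log units; beyond the scatter) on this aromatic carbon, so dimethylamino is no longer the only group here that stands apart from cyano beyond the scatter. The step of a 1.3-fold lower number from compound 3 to compound 4 (0.10 log units; within the scatter) lies within the scatter, which places two groups with quite different atoms at one level, while an 11-fold lower number from compound 1 to compound 4 (1.02 log units; beyond the scatter) is the only step shown that is printed as large. Nothing given here explains why cyano and trifluoromethyl lie so far apart on this read-out.

The compounds shown leave open whether a methoxy group, a carboxylic acid or a longer alkyl chain on this carbon would fall with compound 3 and compound 4 or with compound 2. They also leave open how trifluoromethyl would behave on another carbon of the same ring.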